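This account rests on a few compounds, and the source may have more. Where it says the series, first, only, none or still open, it means among the compounds named here.

Within an ADME assay on HEK-293T cells (Homo sapiens) for antiproliferative activity, read by MTT assay, with a stated time of 48 h, in the presence of a further agent that is not named here (on this read-out higher numbers stand for lower toxicity in this test and lower numbers for higher toxicity in this test), compound 3 `O=C(NOCc1ccccc1F)c1cn(-c2ccccc2)nc1-c1ccc(Cl)cc1` gives 126000 nM, the second highest of the three numbers measured. Compound 2 `O=C(NOCc1ccccc1)c1cn(-c2ccccc2)nc1-c1ccc(Cl)cc1` gives 51900 nM, and compound 1 `COc1ccc(-c2nn(-c3ccccc3)cc2C(=O)NOCc2ccc(Cl)cc2Cl)cc1` gives 545000 nM, the highest number in the set. The step to compound 4 `O=C(NOCc1ccc(Cl)cc1Cl)c1cn(-c2ccccc2)nc1-c1ccc(Cl)cc1` is 2,4-dichlorophenyl in place of 2-fluorophenyl on a saturated chain carbon bound to an oxygen. Going by the values given here, the only measured step touching this position, a 2.4-fold higher number from compound 2 to compound 3 (0.39 log units; beyond the scatter), concerns a smaller change at the same benzyl group. Among the compounds with values here, compound 1 also carries the 2,4-dichlorobenzyl group, though it differs elsewhere, so no single measured step matches. A further rise beyond the scatter is expected, a 2.0-fold higher number from compound 3 to compound 4 (0.30 log units; within the scatter). Compound 4 is therefore estimated at 250000 nM, with a range of 90000 nM to 700000 nM.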

Compound 4, half-maximal cytotoxic concentration: 46300 nM
Compound 4: middle estimate off by 5.4-fold (0.73 log units), on the high side, outside the stated range (below it).
By their numbers in this assay, from the lowest: compounds 4 and 2 (each within the scatter of the next); then compound 3; then compound 1.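

In this assay, the step of a 2.7-fold lower number from compound 3 to compound 4 (0.43 log units; beyond the scatter) runs opposite to the rise seen with the single fluoro, so that rise does not extend to 2,4-dichlorophenyl. The step of a 1.1-fold lower number from compound 2 to compound 4 (0.05 log units; within the scatter) leaves this group and plain phenyl unseparated at this position. With 2,4-dichlorobenzyl held fixed, the step of a 12-fold lower number from compound 1 to compound 4 (1.07 log units; beyond the scatter) is the largest here and comes from chloro in place of methoxy on an aromatic carbon. No evidence bears on the reason for these numbers. Still open, on these data alone, is how an amine or carboxylic acid on the benzyl group would read.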